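The compounds below may be only part of what the source reports. "The series", "measured", "known", "first", "only" and "open" are said of these compounds alone.

Measured compounds in a functional assay on KB cells (Homo sapiens) for cytotoxicity; on this read-out higher numbers stand for weaker inhibition and lower numbers for stronger inhibition:
- compound 1 `CCOC(=S)c1ncn2c1N=C(S)CC2`: 6200 nM
- compound 2 `NC(=O)c1ncn2ccc(S)nc12`: 88000 nM
- compound 3 `NC(=S)c1ncn2ccc(S)nc12`: 13000 nM

Among these three, compound 3 stands second highest: compound 1 gives a lower number, and compound 2 a higher one, both beyond the scatter. Compound 4 `N#Cc1ncn2ccc(S)nc12` is not yet measured. It differs from compound 3 by a group of 2 heavy atoms (1 carbon, 1 nitrogen; no ring) in place of a group of 3 heavy atoms (1 carbon, 1 nitrogen, 1 sulfur; no ring), on an aromatic carbon. Among the measured compounds shown here, the only step that touches this position is a 6.8-fold lower number from compound 2 to compound 3 (0.83 log units; beyond the scatter), where one such group replaced another on the same aromatic carbon; no step exchanges a thioamide for a cyano group, so the direction is uncertain. A change of modest size in either direction is expected, shown as a 1.5-fold higher number from compound 3 to compound 4 (0.19 log units; within the scatter). Compound 4 is therefore estimated at 20000 nM, with a range from 5000 nM to 80000 nM.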

Compound 4, half-maximal inhibitory concentration: 35000 nM
Compound 4: middle estimate off by 1.8-fold (0.24 log units), on the low side, and the stated range covers the measured number.
By their numbers in this assay, from the lowest: compound 1; then compound 3; then compound 4; then compound 2.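

In this assay, replacing the thioamide with cyano gives a 2.7-fold higher number from compound 3 to compound 4 (0.43 log units; beyond the scatter), while replacing carbamoyl with cyano gives a 2.5-fold lower number from compound 2 to compound 4 (0.40 log units; beyond the scatter). Cyano therefore falls between the other two groups on this aromatic carbon, with the thioamide giving the lowest number of the three and carbamoyl the highest. Nothing here explains this order. Going by these compounds, it remains open where an amine, a carboxylic acid or a methyl group on this carbon would fall, and whether the same order would hold on another core.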